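Chloro for hydrogen on two ketone cores

The source may report more compounds than this note shows. Statements on the series, on what has been measured and on what is new or still open speak of the compounds shown alone.

The measured compounds:
Compound 1, `O=C(/C(=C/c1ccccc1)CCl)c1ccccc1`: 3600 nM
Compound 2, `O=C(/C(=C/c1ccc(Cl)cc1)CCl)c1ccccc1`: 3900 nM
Compound 3, `CC(=O)OC/C(=C\C1CCCCC1)C(=O)c1ccccc1`: 19000 nM

In a functional assay on SW1573 cells (Homo sapiens) for inhibition, read by sulforhodamine B assay, with a stated time of 48 h (a lower number here means a stronger inhibitor of growth, a higher number a weaker inhibitor of growth), compound 1 gives 3600 nM, and compound 2 gives 3900 nM. Compound 2 differs from compound 1 by chloro in place of hydrogen on an aromatic carbon. The step of a 1.1-fold higher number from compound 1 to compound 2 (0.03 log units; within the scatter) is small and within the scatter of this assay, so the two values say nothing about a direction.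

Compound 3 gives 19000 nM in this assay, the highest of the three numbers. Compound 3 and compound 1 differ in more than one place, and the difference between the two cores is not broken down here. What can be said is that compound 3 lies beyond the scatter from both compound 1 and compound 2, its nearest neighbour being compound 2.

Compound 4, `CC(=O)OC/C(=C\C1CCCCC1)C(=O)c1ccc(Cl)cc1`, has not been measured in this assay. It differs from compound 3 by chloro in place of hydrogen on an aromatic carbon. This is the same change that separates compound 2 from compound 1, at a place described in the same words, though on a different core. Because the step of a 1.1-fold higher number from compound 1 to compound 2 (0.03 log units; within the scatter) stayed within the scatter, compound 4 is expected to sit close to compound 3, with an estimated step of a 1.1-fold higher number from compound 3 to compound 4 (0.02 log units; within the scatter). For compound 4 the estimate in this assay is 20000 nM, expected to lie between 9000 nM and 45000 nM.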

Compound 4, concentration for 50% growth inhibition: 18000 nM
For compound 4 the middle estimate is 1.1-fold (0.05 log units) above the measured one; the range from low to high includes it.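

In this assay the new step is a 1.1-fold lower number from compound 3 to compound 4 (0.02 log units; within the scatter), so chloro in place of hydrogen on an aromatic carbon leaves the number level on this second core, as it did on the first. Set side by side, the two steps do not differ, and the change carries over from one core to the other as a step too small to read: the same change on two cores in this assay, a 1.1-fold higher number (0.03 log units; within the scatter) from compound 1 to compound 2 and a 1.1-fold lower number (0.02 log units; within the scatter) from compound 3 to compound 4, 1.1-fold (0.06 log units) apart, within the scatter of two such steps This shows only that phenyl to 4-chlorophenyl makes no measurable difference on these two cores in this one assay; it does not show that the same would hold on a third core, and with both steps within the scatter, it offers no effect of any size that could be said to transfer.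

The compounds shown leave open whether another group in the same place, such as methoxy, an amine or a carboxylic acid, would also leave the number level on either core. They also leave open which of the several differences between the two cores goes with the gap between compound 1 and compound 3, since no compound shown separates those differences one at a time.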